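The source may hold more compounds than are shown below. What is called first, only, known or untested is meant among the compounds shown, and "the series" means these compounds.

Compound 1, `N#CC1=C(N)Oc2c(c3nc4ccccc4nc3c3ccccc23)C12C(=O)N(Cc1cnnn1-c1ccc(F)cc1)c1ccccc12`, was tested in a functional assay on A549 cells (Homo sapiens) for antiproliferative activity, read by MTT assay, with a stated time of 48 h (a higher number here means a weaker inhibitor, a lower number a stronger inhibitor), and compound 1 returned only the limit > 50000 nM, not a number. Compound 2, `CCc1ccccc1-n1nncc1CN1C(=O)C2(C(C#N)=C(N)Oc3c(N)cc4nc5ccccc5nc4c32)c2ccccc21`, gives 24600 nM in this assay. Among the compounds with values here, compound 2 therefore stands as the one compound with an actual number in this assay, the other value shown being a limit, (the limit of > 50000 nM in this assay, at which 1 of the 2 values shown sits). Compound 3, `Cc1ccc(C)c(-n2nncc2CN2C(=O)C3(C(C#N)=C(N)Oc4c(N)cc5nc6ccccc6nc5c43)c3ccccc32)c1`, differs from compound 2 in a single place: 2,5-dimethylphenyl in place of 2-ethylphenyl on an aromatic nitrogen. The two have the same atoms, joined differently. Within the data shown here, no pair of measured compounds separated by one change is available, so the size of this step has no measured counterpart to lean on. Given that compound 2 stands at 24600 nM, the change is expected to move the result by no more than the usual scatter, an expected step of a 1.0-fold higher number from compound 2 to compound 3 (0.01 log units; within the scatter) in this assay, in neither direction in particular. Compound 3 is accordingly estimated at 25000 nM in this assay, within 8000 nM to 80000 nM, with a real chance that only a limit is returned.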

Compound 3, half-maximal inhibitory concentration: > 50000 nM
Compound 3 ended at the assay's limit; the forecaster's own chance of this, stated with the estimate: 30%; at least 2.0-fold (0.30 log units) between middle value and limit.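

Within the data shown here, the change of 2-ethylphenyl to 2,5-dimethylphenyl on the aromatic nitrogen gives the first single-change comparison at this position in this assay, with an at least 2.0-fold higher number from compound 2 to compound 3 (0.30 log units; that floor lies within the scatter). The two groups have the same heavy-atom count and the same counts of hydrogen-bond donors and acceptors, yet this rearrangement of the same carbon atoms yields a limit where compound 2 gave a number, although the printed floor of the step does not establish a real difference. Compound 3 gives only a limit, not a number, and such limits now make up most of the values shown: the limit of > 50000 nM in this assay, at which 2 of the 3 values shown sit.

From the compounds shown here alone, the true value of compound 3 remains unknown, so the step could be anywhere from within the scatter to far beyond it. Also open, going by these compounds, is how this position responds to other groups on the aromatic nitrogen, such as an unsubstituted phenyl, a 2-methoxyphenyl, a 2-aminophenyl or a benzyl, and whether any of them would return a number in this assay.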